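The source may report more compounds than this note shows. Statements on the series, on what has been measured and on what is new or still open speak of the compounds shown alone.

Of the compounds shown here, three have been measured so far in a functional assay on cells (Lymphocyte), read by a luciferase reporter and ATP content, with a stated time of 48 h, tested at 5 uM; on this read-out lower numbers stand for a stronger effect and higher numbers for a weaker effect at the one concentration tested. Compound 1, `CCCCCCCCCCCCCCCCc1c(C)c(N(C)C)nc(C)c1O`, gives 96%. Compound 2, `CCCCCCCCCCCCCCCCCCCc1c(C)c(N(C)C)nc(C)c1O`, gives 106%. Compound 3, `CCCCCCCCCCCCCCCCCCCc1nc(N(C)C)c(C)c(C)c1O`, gives 102%.

Compound 2 and compound 1 differ by one change, (hydrogen in place of propyl on a saturated chain carbon, ten or more bonds along the chain from an aromatic carbon), and this change made a step of a number 10 percentage points lower from compound 2 to compound 1 (within the scatter). Compound 2 and compound 3 have the same atoms joined differently; the difference between the two cores is not broken down here, and the two values lie within the scatter of each other. Compound 4, `CCCCCCCCCCCCCCCCc1nc(N(C)C)c(C)c(C)c1O`, is not yet measured. It differs from compound 3 by hydrogen in place of propyl on a saturated chain carbon, ten or more bonds along the chain from an aromatic carbon, the same change as from compound 2 to compound 1. Because that earlier step was a number 10 percentage points lower from compound 2 to compound 1 (within the scatter), the step of a number 4 percentage points lower from compound 3 to compound 4 (within the scatter) is expected to be of similar small size. Compound 4 is therefore estimated at 98%, in the range 86% to 110%.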

Compound 4, a percentage reported as activity, at one concentration (the size of the read-out at that concentration, not a potency): 100%
Beside the measured number, compound 4's estimate is 2 percentage points below it, and the stated range covers the measured number.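

In this assay, putting hydrogen in place of propyl on a saturated chain carbon gave a step of a number 2 percentage points lower from compound 3 to compound 4 (within the scatter). Set beside the earlier step, the change reads alike on the two cores: the same change on two cores in this assay, a number 10 percentage points lower (within the scatter) from compound 2 to compound 1 and a number 2 percentage points lower (within the scatter) from compound 3 to compound 4, 8 percentage points apart, within the scatter of two such steps This shows agreement between two small steps, but it does not show that the change has a real effect in this assay, nor that the same would hold on any other core.

The compounds shown leave open how a much shorter chain, such as butyl, would read on either core. They also leave open what a chain carrying an amine or a carboxylic acid would give.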